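Swapping the aryl group on a sulfur linker

This account rests on a few compounds, and the source may have more. Where it says the series, first, only, none or still open, it means among the compounds named here.

Compound 3 (`COc1ccc(Sc2nc3cc(N)cc(N)c3nc2-c2ccccc2)cc1`) carries a (4-methoxyphenyl)sulfanyl group on its shared core. In a functional assay on U-251 cells (Homo sapiens) for inhibition, read by sulforhodamine B assay, with a stated time of 48 h (on this read-out lower numbers stand for higher toxicity in this test and higher numbers for lower toxicity in this test), compound 3 reaches only the limit < 100000 nM, so the measurement gives no exact number, only a boundary (the limit of < 100000 nM in this assay, at which 1 of the 3 values shown sits). Compound 4 (`Nc1cc(N)c2nc(-c3ccccc3)c(Sc3ccc(Cl)c(Cl)c3)nc2c1`) is not yet measured; it differs from compound 3 by 3,4-dichlorophenyl in place of 4-methoxyphenyl on a sulfur. The measured steps that touch the same position are a step that the limit leaves unreadable from compound 1 to compound 3 and a step that the limit leaves unreadable from compound 2 to compound 3, and both run into the limit of compound 3, so neither gives a usable size. Compound 1 (`Nc1cc(N)c2nc(-c3ccccc3)c(Oc3ccc(Cl)c(Cl)c3)nc2c1`) carries the 3,4-dichlorophenyl group through an oxygen and gives 83200 nM in this assay, and compound 2 (`Nc1cc(N)c2nc(-c3ccccc3)c(NCc3ccc(F)cc3)nc2c1`) gives 6310 nM. Taken together these numbers leave the expectation for compound 4 open, and compound 4 is estimated at 80000 nM, with a range from 30000 nM to 150000 nM. The expected step is a step that the limit leaves unreadable from compound 3 to compound 4, which cannot be read against a limit.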

Compound 4, concentration lethal to 50% of the cells: < 100000 nM
Compound 4: a limit, no number; the forecaster's own chance of this, stated with the estimate: 35%; the middle value is on the limit's open side.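

Within the data shown here, compound 4, like compound 3, gives only a limit and no exact number in this assay, so no step to compound 4 from compound 1, compound 2 or compound 3 can be read: the limit of < 100000 nM in this assay, at which 2 of the 4 values shown sit. The compounds shown leave open how far the 3,4-dichlorophenyl and 4-methoxyphenyl groups on the sulfur differ in toxicity in this test.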